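This account rests on a few compounds, and the source may have more. Where it says the series, first, only, none or still open, it means among the compounds named here.

Compound 3, with structure `CCCCNc1nc(N)nc(C)c1CCCC(C)(C)O`, stands at the top of the three numbers measured in an assay on HEK293 cells for agonist activity at Toll-like receptor 8 (Homo sapiens), read by spectrophotometry; on this read-out higher numbers stand for an effect only at larger amounts of compound and lower numbers for an effect already at smaller amounts: compound 3 gives 1220 nM, while compound 1, structure `CCCCNc1nc(N)nc(C)c1CCCCc1ccccc1`, gives 857 nM and compound 2, structure `CCCCNc1nc(N)nc(C)c1CCCN1CCN(C)CC1`, gives 179 nM. Compound 4, structure `CCCCNc1nc(N)nc(C)c1CCCN(C)C`, is not yet measured; it differs from compound 3 by dimethylamino in place of 1-hydroxy-1-methylethyl on a saturated chain carbon, three bonds along the chain from an aromatic carbon.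

For the measured compounds named here, two measured steps bear on this change. The step of a 6.8-fold higher number from compound 2 to compound 3 (0.83 log units; beyond the scatter) shows that exchanging the amine-bearing 4-methylpiperazin-1-yl for the 1-hydroxy-1-methylethyl moved the number clearly upward, and the step of a 4.8-fold lower number from compound 1 to compound 2 (0.68 log units; beyond the scatter) shows that bringing in that same amine-bearing group moved the number clearly downward. The step from compound 1 to compound 3 lay within the scatter. Compound 4 carries a dimethylamino, an amine-bearing group like that of compound 2, so a downward step in this assay is expected, of the order of a 4.9-fold lower number from compound 3 to compound 4 (0.69 log units; beyond the scatter). Compound 4 is therefore estimated at 250 nM, within a range from 100 nM to 700 nM.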

Compound 4, half-maximal effective concentration: 126 nM
The estimate for compound 4 lay 2.0-fold (0.30 log units) above the measured number, within the range that was stated.
By their numbers in this assay, from the lowest: compounds 4 and 2 (each within the scatter of the next); then compounds 1 and 3 (each within the scatter of the next).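

In this assay, the small dimethylamino group matches the larger 4-methylpiperazin-1-yl: a 1.4-fold lower number from compound 2 to compound 4 (0.15 log units; within the scatter), so the full ring of compound 2 is not needed at this position. Dimethylamino also stands clearly apart from the two groups without nitrogen, with a 9.7-fold lower number from compound 3 to compound 4 (0.99 log units; beyond the scatter) and a 6.8-fold lower number from compound 1 to compound 4 (0.83 log units; beyond the scatter), so the four compounds fall into two sets, those with an amine at this place and those without, and none goes against this split. Nothing available explains why the amine-bearing compounds sit apart.

From the compounds shown here alone, it remains open whether a primary amine or a pyrrolidine ring would fit the same pattern. Also open, going by these compounds, is how a shorter or longer chain carrying the dimethylamino group would change the number.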